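A few compounds are considered here, and "the series" means these few. Any claim that something is new, unique, unknown or untested is made for them only; others in the source may bear on it.

Measured so far:
- compound 1, `CC(C)CNC(=O)/C=C/c1ccccc1`: 78%
- compound 2, `CCC(C)OC(=O)/C=C/c1ccccc1`: 20%

In a functional assay on the whole organism for inhibition, with Brassica rapa subsp. chinensis as the target, with a stated time of 3 days, tested at 100 ppm (on this read-out higher numbers stand for more inhibition of growth at the one concentration tested and lower numbers for less inhibition of growth), compound 1 gives 78%, the higher of the two numbers measured. Going by the values given here, compound 2 gives 20% in this assay, and the step of a number 58 percentage points lower from compound 1 to compound 2 (beyond the scatter) is the only measured step. Among the compounds with values here, it exchanges the group on the carbonyl carbon, so it concerns a different place from the one changed in the step followed here.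

Compound 3, `CCCCCCNC(=O)/C=C/c1ccccc1`, differs from compound 1 by pentyl in place of isopropyl on a saturated chain carbon bound to an amide-type nitrogen. The amide and the rest of the shared core stay as they are in compound 1. Within the data shown here, no measured step touches the chain on the amide-type nitrogen, so the data give no direct guide to the size of this step. Among the measured compounds shown here, since the one large change that was measured lies elsewhere, the expectation is that compound 3 stays near compound 1, with any step from compound 1 to compound 3 expected to be small, a number 6 percentage points lower from compound 1 to compound 3 (within the scatter), and not clearly beyond the scatter. Compound 3 is therefore estimated at 72%, with a range from 50% to 90%.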

Compound 3, percent growth inhibition at one concentration: 82%
Beside the measured number, compound 3's estimate is 10 percentage points below it; the range from low to high includes it.
By their numbers in this assay, from the lowest: compound 2; then compounds 1 and 3 (each within the scatter of the next).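

In this assay, the exchange of isopropyl for pentyl on a saturated chain carbon bound to an amide-type nitrogen gives a number 4 percentage points higher from compound 1 to compound 3 (within the scatter), so the two compounds cannot be told apart. Going by these compounds alone, the only step measured earlier, a number 58 percentage points lower from compound 1 to compound 2 (beyond the scatter), concerned the group on the carbonyl carbon and said nothing about this chain; the new step shows that here, with the amide and the rest of the shared core kept, a group of 3 heavy atoms and one of 5 heavy atoms give numbers within the usual scatter in this test of growth inhibition. No supporting data are available to explain why these two numbers lie so close.

As far as these compounds go, with only these two groups at this place, it remains open how far this holds for a much longer chain such as decyl, for a ring such as cyclohexyl, or for a chain ending in an amine or a carboxylic acid. From the compounds shown here alone, it also remains open whether pentyl and isopropyl would stay this close at concentrations other than the single one used here.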